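Oxadiazole isomer swap in a bis-sulfonyl piperidine amide series

The source may hold more compounds than are shown below. What is called first, only, known or untested is meant among the compounds shown, and "the series" means these compounds.

Measured compounds:
compound 1 `CC(C)c1noc(N2CCN(C(=O)[C@@H]3CCCN(S(=O)(=O)c4ccc(S(=O)(=O)C5CCC5)cc4)C3)CC2)n1` — in a functional assay on MIA PaCa-2 cells (Homo sapiens) for inhibition, read by MTT assay, with a stated time of 3 days (a lower number here means a stronger inhibitor, a higher number a weaker inhibitor), compound 1 gives > 10000 nM, which is a limit of the assay and not a number.
compound 2 `CCN(CC)C(=O)c1ccc(S(=O)(=O)N2CCC[C@@H](C(=O)N3CCN(c4nc(C(C)C)no4)CC3)C2)cc1` — compound 2 gives > 10000 nM, again only a limit.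
compound 3 `CCN(CC)S(=O)(=O)c1ccc(S(=O)(=O)N2CCC[C@@H](C(=O)N3CCN(c4nnc(C(C)C)o4)CC3)C2)cc1` — compound 3 gives > 10000 nM, likewise a limit.

Compound 3 therefore stands at the limit, with no number of its own, and it shares that position with both other measured compounds (the limit of > 10000 nM in this assay, at which 3 of the 3 values shown sit). Going by the values given here, the only step between measured compounds that differ in one place, a step that the two limits leave unreadable from compound 1 to compound 2, cannot be read because both of its ends sit at the limit of > 10000 nM in this assay, at which 3 of the 3 values shown sit. Nothing in the measured set gives a readable step of any size.

Compound 4 `CCN(CC)S(=O)(=O)c1ccc(S(=O)(=O)N2CCC[C@@H](C(=O)N3CCN(c4nc(C(C)C)no4)CC3)C2)cc1` differs from compound 3 by 3-isopropyl-1,2,4-oxadiazol-5-yl in place of 5-isopropyl-1,3,4-oxadiazol-2-yl on an amine nitrogen in a ring. Among the compounds with values here, no measured step covers this change directly. Compound 1 already carries the entering 3-isopropyl-1,2,4-oxadiazol-5-yl group and shows only a limit. Compound 2 carries the same group and also shows only a limit. The swap between the two oxadiazole isomers thus has no measured bearing, and the surrounding compounds give no reason to expect a number to appear.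

Compound 4 is expected to remain at the limit in this assay, estimated at 20000 nM with a range from 8000 nM to 100000 nM. The step that the limit leaves unreadable from compound 3 to compound 4 is expected to be none beyond the scatter.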

Compound 4, half-maximal inhibitory concentration: > 10000 nM
Compound 4: only a limit was reported; the forecaster's own chance of this, stated with the estimate: 85%; the middle value is on the limit's open side.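

The steps from compound 1, compound 2 and compound 3 to compound 4 cannot be read in this assay, because each of their ends is a limit and not a number: the limit of > 10000 nM in this assay, at which 4 of the 4 values shown sit.

Going by these compounds, whether the swap between the two oxadiazole isomers, or the exchange among the diethylsulfamoyl, diethylcarbamoyl and cyclobutylsulfonyl groups, alters inhibition in this assay remains open.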